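This account rests on a few compounds, and the source may have more. Where it says the series, first, only, none or still open, it means among the compounds named here.

Working notes on the series. In an assay on isolated protein for inhibition of aldehyde dehydrogenase 1A1 (Homo sapiens), read by spectrophotometry, tested at 10 uM (on this read-out higher numbers stand for more inhibition at the one concentration tested (going by the name of the read-out) and lower numbers for less inhibition), compound 1 `CC(C)=CCn1c(CN2CCN(C(=O)C3CC3)CC2)nc2ccccc21` gives 74.3%, the highest of the three numbers to hand. Compound 2 `Cc1cccc(Cn2c(OC3CCN(C(=O)c4ccco4)CC3)nc3ccccc32)c1` gives 68.3%, which lies within the scatter of compound 1, so no order between the two is claimed. Compound 3 `Cc1cccc(Cn2c(CN3CCN(C(=O)c4ccncc4)CC3)nc3ccccc32)c1` gives 20.6%, a gap to compound 1 well beyond the scatter. Compound 4 `O=C(C1CC1)N1CCN(Cc2nc3ccccc3n2Cc2ccc(F)cc2)CC1` is not yet measured in this assay; it differs from compound 1 by 4-fluorophenyl in place of 2-methylprop-1-en-1-yl on a saturated chain carbon bound to an aromatic nitrogen. Going by the values given here, no measured pair isolates this change, so the expectation rests on compound 1 alone. A modest fall in this assay is expected, about a number 14.3 percentage points lower from compound 1 to compound 4 (beyond the scatter), not clearly beyond the scatter. Compound 4 is therefore estimated at 60%, with a range from 35% to 85%.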

Compound 4, a percentage reported as inhibition, at one concentration (the size of the read-out at that concentration, not a potency): 32.7%
Compound 4: the middle estimate sits 27.3 percentage points above what was measured; the measured number lies below the stated range.
By their numbers in this assay, from the lowest: compound 3; then compound 4; then compounds 2 and 1 (each within the scatter of the next).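

Putting 4-fluorophenyl in place of 2-methylprop-1-en-1-yl on a saturated chain carbon bound to an aromatic nitrogen gives a number 41.6 percentage points lower from compound 1 to compound 4 (beyond the scatter) in this assay. Going by these compounds alone, this is the first pair to isolate a single change, and it shows that inhibition is sensitive to the group at this position when the rest of compound 1 is held fixed. Nothing to hand accounts for the fall.

The compounds shown leave open whether the fall goes with the aromatic ring or with the fluorine. On these data alone, how a plain benzyl or a saturated 3-methylbutyl chain would read at this position also remains open.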